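Swapping the Urea Aryl Group of Compound 1

A few compounds are considered here, and "the series" means these few. Any claim that something is new, unique, unknown or untested is made for them only; others in the source may bear on it.

Compound 1, `O=C(Nc1cccc(-n2cc(-c3ccncc3)c(-c3ccc(Cl)c(O)c3)n2)c1)Nc1ccc(Cl)c(Cl)c1`: 1230 nM
Compound 2, `COc1cc(-c2nn(-c3cccc(NC(=O)c4ccccc4)c3)cc2-c2ccncc2)ccc1Cl`: 654 nM

Of the compounds shown here, two have been measured in a functional assay on HCT-15 cells (Homo sapiens) for inhibition, read by sulforhodamine B assay, with a stated time of 48 h; on this read-out lower numbers stand for stronger inhibition of growth and higher numbers for weaker inhibition of growth. Compound 1 gives 1230 nM and compound 2 gives 654 nM; these two numbers lie within the scatter of each other, so compound 1 is not separated from compound 2, and no ordering of the pair can be read from them. Going by the values given here, compound 2 shares no single-point relation with compound 1, so the two offer no step to build on.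

The unmeasured compound 3, `O=C(Nc1cccc(-n2cc(-c3ccncc3)c(-c3ccc(Cl)c(O)c3)n2)c1)Nc1cccc(C(F)(F)F)c1`, differs from compound 1 at one place: 3-(trifluoromethyl)phenyl in place of 3,4-dichlorophenyl on an amide-type nitrogen. Among the compounds with values here, no measured pair shows this kind of swap, so the expectation rests only on compound 1 itself. The step from compound 1 to compound 3 in this assay is expected to be small and within the scatter, as a 1.2-fold higher number from compound 1 to compound 3 (0.09 log units; within the scatter). Compound 3 is therefore estimated at 1500 nM, with a range from 500 nM to 4500 nM.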

Compound 3, concentration for 50% growth inhibition: 1510 nM
For compound 3 the middle estimate is 1.0-fold (0.00 log units) below the measured one; measured number inside the range.
By their numbers in this assay, from the lowest: compounds 2, 1 and 3 (each within the scatter of the next, the first and the last beyond it).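

In this assay, placing 3-(trifluoromethyl)phenyl in place of 3,4-dichlorophenyl on an amide-type nitrogen gives a 1.2-fold higher number from compound 1 to compound 3 (0.09 log units; within the scatter). Going by these compounds alone, this is the first step that isolates a single place, which the unrelated pair of compound 1 and compound 2 could not do, and it shows that these two aryl groups cannot be told apart here, even though they differ in their substituents and the entering group is larger by heavy-atom count. Nothing measured bears on why the two groups read alike.

Within the data shown here, this single step covers only two substituted phenyl groups on that nitrogen, so it sets no general rule for the place. As far as these compounds go, whether a group of another kind there, such as a carboxylic acid, an amine or a longer alkyl chain, would also stay within the scatter of compound 1 remains open.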